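This account rests on a few compounds, and the source may have more. Where it says the series, first, only, none or still open, it means among the compounds named here.

Measured so far:
- compound 1 `N#Cc1c(Nc2ccccc2)nc(SCc2nc3ccccc3[nH]2)nc1-c1ccccc1`: 4.46 nM
- compound 2 `CCNc1nc(SCc2nc3ccccc3[nH]2)nc(-c2ccccc2)c1C#N`: 7.35 nM

Both values come from a functional assay on SF-268 cells (Homo sapiens) for cytotoxicity, read by MTT assay, with a stated time of 3 days; on this read-out higher numbers stand for weaker inhibition and lower numbers for stronger inhibition. Only these two compounds have been measured, and compound 2 cannot be told apart from compound 1, since the difference is a 1.6-fold higher number from compound 1 to compound 2 (0.22 log units; within the scatter).

Among the compounds with values here, the next compound to consider is compound 3 `N#Cc1c(NC(N)=S)nc(SCc2nc3ccccc3[nH]2)nc1-c1ccccc1`, which has no measurement yet. The change leading to it is a group of 3 heavy atoms (1 carbon, 1 nitrogen, 1 sulfur; no ring) in place of a group of 2 heavy atoms (2 carbon; no ring), on a nitrogen on an aromatic ring, on a nitrogen on an aromatic ring.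

Within the data shown here, only one measured step bears on this. It sits at the same place, with ethyl in place of phenyl on that nitrogen, and it is a 1.6-fold higher number from compound 1 to compound 2 (0.22 log units; within the scatter). That single step suggests this place tolerates exchange, so no shift beyond the scatter is expected in this assay. The evidence is thin, however. Among the measured compounds shown here, no measured compound carries the entering group, and the range has to stay wide.

The expected change is a 1.1-fold lower number from compound 2 to compound 3 (0.02 log units; within the scatter). For compound 3 the estimated value is 7 nM, with an expected range from 2 nM to 25 nM.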

Compound 3, half-maximal inhibitory concentration: 3.37 nM
Estimate against measurement, compound 3: 2.1-fold (0.32 log units) above; the range from low to high includes it.
By their numbers in this assay, from the lowest: compounds 3, 1 and 2 (each within the scatter of the next, the first and the last beyond it).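

In this assay, within the data shown here, the group of 3 heavy atoms (1 carbon, 1 nitrogen, 1 sulfur) gives the first step on this nitrogen that goes beyond the scatter, a 2.2-fold lower number from compound 2 to compound 3 (0.34 log units; beyond the scatter), so replacing ethyl here has a modest but readable effect. Replacing phenyl with the same group gives a 1.3-fold lower number from compound 1 to compound 3 (0.12 log units; within the scatter), which leaves compound 3 and compound 1 indistinguishable, even though one carries an open group with a hydrogen-bond donor and acceptor and the other a six-membered aromatic ring with neither. No measurement shown here explains why one exchange registers and the other does not.

All three groups at this place give numbers that lie close together, so the compounds shown do not reveal whether any substituent on this nitrogen can move the number much further in either direction. As far as these compounds go, it remains open whether a longer chain such as butyl, a smaller methyl, or a carboxylic acid carried on a short chain would stay in this narrow band or fall clearly outside it.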